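The source may report more compounds than this note shows. Statements on the series, on what has been measured and on what is new or still open speak of the compounds shown alone.

For the measured compounds named here, in a functional assay on CCRF-CEM cells (Homo sapiens) for inhibition (a higher number here means a weaker inhibitor, a lower number a stronger inhibitor), compound 1 (`O=C1CCCCC/C1=C\c1cccc(F)c1`) gives 224000 nM and compound 2 (`O=C1CCCCC/C1=C\c1cccc(Cl)c1`) gives 40500 nM, the lower of the two numbers so far. The change to compound 3 (`O=C1CCCCC/C1=C\c1cccc(Br)c1`) is bromo in place of chloro on an aromatic carbon. Going by the values given here, one measured step bears on it: a 5.5-fold lower number from compound 1 to compound 2 (0.74 log units; beyond the scatter), also a swap of one halogen for another on an aromatic carbon. A single pair sets no firm trend, so a smaller move in the same direction is expected in this assay. The expected size is a 1.7-fold lower number from compound 2 to compound 3 (0.23 log units; within the scatter). For compound 3 the estimated value is 24000 nM, with an expected range from 9000 nM to 60000 nM.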

Compound 3, half-maximal inhibitory concentration: 137000 nM
The estimate for compound 3 lay 5.7-fold (0.76 log units) below the measured number; measured number above the stated range.
By their numbers in this assay, from the lowest: compound 2; then compounds 3 and 1 (each within the scatter of the next).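

In this assay the halogen series at this position does not run in one direction: moving on from chloro to bromo gives a 3.4-fold higher number from compound 2 to compound 3 (0.53 log units; beyond the scatter), which takes back much of the earlier gain. The other comparison gives a 1.6-fold lower number from compound 1 to compound 3 (0.21 log units; within the scatter), so bromo and fluoro are not separated and chloro alone stands apart among the three halogens. No data shown here bear on the cause of this result.

Still open, from the compounds shown here alone, is whether chloro's edge extends beyond halogens, for instance against a methyl, methoxy or nitrile on the same aromatic carbon. Going by these compounds, whether it holds at other ring positions also remains open.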